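This account rests on a few compounds, and the source may have more. Where it says the series, first, only, none or still open, it means among the compounds named here.

Compound 1 `CNC(=O)C1CC=CC1n1cnc2c(NC3CC3)ncnc21` stands highest of the two measured compounds: in an assay on cell membranes for displacement of a labelled ligand from adenosine receptor A1 (Rattus norvegicus), tested at 100 uM (a higher number here means more inhibition at the concentration tested (going by the name of the read-out), a lower number less inhibition), compound 1 gives 50%. Compound 2 `CNC(=O)C1CCCC1n1cnc2c(NC3CCCC3)ncnc21` gives 31% in this assay, a gap beyond the usual scatter of repeated measurements. Compound 3 `CNC(=O)C1CC=CC1n1cnc2c(NCc3ccccc3)ncnc21` differs from compound 1 by benzyl in place of cyclopropyl on a nitrogen on an aromatic ring. Among the compounds with values here, no measured pair isolates this change, so its effect is not known from the data. A modest downward step a number 6 percentage points lower from compound 1 to compound 3 (within the scatter) is expected, of a size near the scatter. For compound 3 the expected inhibition is 44%, with a range from 22% to 68%.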

Compound 3, a percentage reported as inhibition, at one concentration (the size of the read-out at that concentration, not a potency): < 10%
Compound 3 was reported as a limit; the forecaster's own chance of this, stated with the estimate: 2%; middle value at least 34 percentage points away from the limit.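

Within the data shown here, with benzyl in place of cyclopropyl on a nitrogen on an aromatic ring, this assay shows a number at least 40 percentage points lower from compound 1 to compound 3 (beyond the scatter), the first single-place change. This position therefore responds strongly to the group it carries. The step has only a lower bound on its size, as compound 3 sits at a limit: the limit of < 10% in this assay, at which 1 of the 3 values shown sits.

The compounds shown leave open whether the aromatic ring or the larger group accounts for the step. A cyclohexyl group or a plain phenyl on the same nitrogen would separate the two.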